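Methoxy for Methyl on a Pyridazine: What to Expect

The compounds below may be only part of what the source reports. "The series", "measured", "known", "first", "only" and "open" are said of these compounds alone.

Compound 1, `O=C(Nc1nc2ccc(F)cc2s1)N1CCN(c2ccc(Cl)nn2)CC1`: in an assay on HEK293 cells for inhibition of transient receptor potential cation channel subfamily V member 1 (Homo sapiens), read by FLIPR (on this read-out lower numbers stand for stronger inhibition and higher numbers for weaker inhibition), compound 1 gives > 10000 nM, which is a limit of the assay and not a number.
Compound 2, `Cc1ccc(N2CCN(C(=O)Nc3nc4ccc(F)cc4s3)CC2)nn1`: in this assay compound 2 gives > 10000 nM, likewise a limit of the assay.

Compound 2 therefore stands at the limit of this assay, with no measured number behind it. For the measured compounds named here, the one measured step, a step that the two limits leave unreadable from compound 1 to compound 2, cannot be read in size, because both of its values sit at the same point, (the limit of > 10000 nM in this assay, at which 2 of the 2 values shown sit).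

Compound 3, `COc1ccc(N2CCN(C(=O)Nc3nc4ccc(F)cc4s3)CC2)nn1`, differs from compound 2 by methoxy in place of methyl on an aromatic carbon. Going by the values given here, the only measured step at this carbon, a step that the two limits leave unreadable from compound 1 to compound 2, bears directly on the site but gives no readable size, so there is nothing in the measured steps to suggest that a change here moves the read-out. Compound 3 is accordingly expected to sit at or beyond the same limit, and the step that the limit leaves unreadable from compound 2 to compound 3 is estimated as none beyond the scatter. For compound 3 the estimate in this assay is 15000 nM, with a range from 5000 nM to 50000 nM.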

Compound 3, half-maximal inhibitory concentration: > 10000 nM
Compound 3 gave a limit, no number (the forecaster's own chance of this, stated with the estimate: 85%); the middle value lies beyond the limit too.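

In this assay compound 3 gives > 10000 nM, which is a limit of the assay and not a number. Its steps from compound 1 and from compound 2 therefore cannot be read in size, because all the values shown sit at one point: the limit of > 10000 nM in this assay, at which 3 of the 3 values shown sit.

The compounds shown leave open whether chloro, methyl or methoxy at this carbon changes the inhibition at all.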